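The source may report more compounds than this note shows. Statements on the series, on what has been measured and on what is new or still open speak of the compounds shown alone.

Three compounds share one core and differ only in the group attached to it. Compound 1 `CC(C)(C)n1cc2c(n1)C(=O)CC1(CCN(C(=O)c3cc(-c4ccc(Cl)cc4)nc4ccccc34)CC1)O2` carries a chloro group, compound 2 `CC(C)(C)n1cc2c(n1)C(=O)CC1(CCN(C(=O)c3cc(-c4ccc(F)cc4)nc4ccccc34)CC1)O2` a fluoro group, and compound 3 `COc1ccc(-c2cc(C(=O)N3CCC4(CC3)CC(=O)c3nn(C(C)(C)C)cc3O4)c3ccccc3n2)cc1` a methoxy group, each on an aromatic carbon. In a functional assay on MDA-MB-231 cells (Homo sapiens) for inhibition, read by MTT assay, with a stated time of 72 h (on this read-out higher numbers stand for weaker inhibition and lower numbers for stronger inhibition), compound 1 gives > 10000 nM, which is a limit of the assay rather than a number. Compound 2 likewise gives only a limit, > 10000 nM. Compound 3 also reaches only a limit, > 10000 nM. Because of the limit of > 10000 nM in this assay, at which 3 of the 3 values shown sit, none of the three steps between them can be read: a step that the two limits leave unreadable from compound 1 to compound 2, a step that the two limits leave unreadable from compound 1 to compound 3 and a step that the two limits leave unreadable from compound 2 to compound 3. Compound 2 therefore stands at the same limit as its two neighbours, with no number of its own.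

Compound 4 `CC(C)(C)n1cc2c(n1)C(=O)CC1(CCN(C(=O)c3cc(-c4ccncc4)nc4ccccc34)CC1)O2` is not yet measured; it differs from compound 2 as follows: pyridin-4-yl in place of 4-fluorophenyl on an aromatic carbon. The measured steps bear on this change only in that three different groups at the same place all left the read-out at the limit, so no direction or size can be taken from them. Compound 4 is therefore expected to sit at about the same place, and the step that the limit leaves unreadable from compound 2 to compound 4 is an estimate only. The estimated value for compound 4 is 15000 nM, with a range from 5000 nM to 50000 nM, and it is expected that this compound too will most likely be reported only as a limit.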

Compound 4, half-maximal inhibitory concentration: 1650 nM
Compound 4: the middle estimate sits 9.1-fold (0.96 log units) above what was measured; measured number below the stated range.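

In this assay, this position proves able to move the read-out: pyridin-4-yl in place of 4-fluorophenyl brings an at least 6.0-fold lower number from compound 2 to compound 4 (0.78 log units; beyond the scatter). The same group gives an at least 6.0-fold lower number from compound 3 to compound 4 (0.78 log units; beyond the scatter) in place of 4-methoxyphenyl and an at least 6.0-fold lower number from compound 1 to compound 4 (0.78 log units; beyond the scatter) in place of 4-chlorophenyl, so among these four compounds only the one with a ring nitrogen in this group gives a real number, and none goes against that pattern. The steps among compounds 1, 2 and 3 still cannot be read, and the three new steps give only a smallest possible size, because the true values of those three compounds are hidden by a limit: the limit of > 10000 nM in this assay, at which 3 of the 4 values shown sit.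

Compound 4 differs from the other three both in having the ring nitrogen and in lacking a fluoro, chloro or methoxy group, and with plain phenyl not among the compounds shown, it stays open which of these two differences goes with the lower number. On these data alone, it also stays open whether pyridin-3-yl or pyrimidin-5-yl would give a similar or a lower number than pyridin-4-yl.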